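Hydroxyphenyl for chlorophenyl on the methylpiperazine core

The source may hold more compounds than are shown below. What is called first, only, known or untested is meant among the compounds shown, and "the series" means these compounds.

Compound 3 `CN1CCN(c2nc(-c3cccc(Cl)c3)nc3c2ncn3C)CC1` carries a 3-chlorophenyl and a 4-methylpiperazin-1-yl group on the shared core. In an assay on cells for displacement of a labelled ligand from adenosine receptor A1 (Homo sapiens), read by scintillation counting and radioligand binding, with a stated time of 60 min, tested at 10 uM (on this read-out lower numbers stand for less inhibition and higher numbers for more inhibition at the one concentration tested (going by the name of the read-out)), compound 3 gives 45.7%. Compound 1 `Cn1cnc2c(N3CCCCC3)nc(-c3ccccc3O)nc21`, which carries a 2-hydroxyphenyl and a piperidine in place of the 4-methylpiperazin-1-yl group, gives 50.5% in this assay; the gap to compound 3 lies within the scatter, so the two numbers stand together. Compound 2 `CN1CCN(c2nc(-c3ccc(Cl)c(Cl)c3)nc3[nH]cnc23)CC1`, with a 3,4-dichlorophenyl on a core lacking the methyl, is recorded in this assay only as a limit, > 80%, and not as a number (the limit of > 80% in this assay, at which 1 of the 3 values shown sits). For the measured compounds named here, no pair of measured compounds differs in a single place, so no measured step size is available.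

Compound 4 `CN1CCN(c2nc(-c3ccccc3O)nc3c2ncn3C)CC1` differs from compound 3 by 2-hydroxyphenyl in place of 3-chlorophenyl on an aromatic carbon. The change sits on an aromatic carbon between two ring nitrogen atoms, meta to the 4-methylpiperazin-1-yl group. For this step no change beyond the scatter is expected in this assay, since compound 1 gives 50.5% with the same 2-hydroxyphenyl while compound 3 gives 45.7%. The expected step of a number 4.3 percentage points higher from compound 3 to compound 4 (within the scatter) is therefore small. Compound 4 is estimated at 50%, with a range from 28% to 72%.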

Compound 4, a percentage reported as inhibition, at one concentration (the size of the read-out at that concentration, not a potency): > 80%
Compound 4 ended at the assay's limit; the forecaster's own chance of this, stated with the estimate: 10%; middle value at least 30 percentage points away from the limit.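

On the aromatic carbon between two ring nitrogen atoms, the aryl group matters more than compound 1 and compound 3 suggested: in this assay, 2-hydroxyphenyl in place of 3-chlorophenyl gives a number at least 34.3 percentage points higher from compound 3 to compound 4 (beyond the scatter). The 4-methylpiperazin-1-yl group also counts with 2-hydroxyphenyl held fixed, since 4-methylpiperazin-1-yl in place of piperidin-1-yl gives a number at least 29.5 percentage points higher from compound 1 to compound 4 (beyond the scatter), so the value of compound 1 did not carry over to the methylpiperazine core. Compound 4 stands at a limit of the assay and not at a number, so both steps give only a floor and their sizes cannot be set against each other: the limit of > 80% in this assay, at which 2 of the 4 values shown sit.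

The step from 3-chlorophenyl to 2-hydroxyphenyl changes both the substituent and its place on the phenyl ring, and a 2-chlorophenyl or a 3-hydroxyphenyl group on the same core would separate the two. Also open, from the compounds shown here alone, is how a morpholine in place of the 4-methylpiperazin-1-yl group would compare with the piperidine and the methylpiperazine while 2-hydroxyphenyl stays fixed.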